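The source may report more compounds than this note shows. Statements on the series, on what has been measured and on what is new or still open speak of the compounds shown alone.

Working notes on the series. Among the measured compounds shown here, compound 1 `CCCN(Cc1sc(Nc2c(C)cc(C)cc2Cl)nc1C(F)(F)F)CC1CC1` in an assay for displacement of a labelled ligand from corticotropin-releasing factor receptor 1 (Homo sapiens) (on this read-out lower numbers stand for stronger inhibition and higher numbers for weaker inhibition), gives 23 nM, the lower of the two numbers so far, though within the scatter of compound 2 `CCCN(Cc1sc(Nc2c(Br)cc(C)cc2Br)nc1C(F)(F)F)CC1CC1`, which in this assay gives 28 nM. For the measured compounds named here, the one measured step, a 1.2-fold higher number from compound 1 to compound 2 (0.09 log units; within the scatter), concerns the aryl group on the nitrogen and leaves the hydrogen on that nitrogen untouched.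

Compound 3 `CCCN(Cc1sc(N(C)c2c(C)cc(C)cc2Cl)nc1C(F)(F)F)CC1CC1` differs from compound 1 by methyl in place of hydrogen on a nitrogen on an aromatic ring. Going by the values given here, no measured step in the set touches this nitrogen, so the size and direction of its effect in this assay have no precedent here; the aryl step between compound 1 and compound 2 does not bear on it. The estimate therefore stays close to compound 1 with a wide range and is expected to correspond to a 2.6-fold higher number from compound 1 to compound 3 (0.42 log units; beyond the scatter). For compound 3 the expected value in this assay is 60 nM, in the range 12 nM to 400 nM.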

Compound 3, inhibition constant: 100 nM
The estimate for compound 3 lay 1.7-fold (0.22 log units) below the measured number; the measured number falls inside the stated range.
By their numbers in this assay, from the lowest: compounds 1 and 2 (each within the scatter of the next); then compound 3.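

In this assay, the nitrogen bearing the aryl group now has a measured step of its own: methyl in place of hydrogen there gives a 4.3-fold higher number from compound 1 to compound 3 (0.64 log units; beyond the scatter), whereas the aryl change gave a 1.2-fold higher number from compound 1 to compound 2 (0.09 log units; within the scatter) and stayed within the scatter. The hydrogen on this nitrogen is therefore not required for a measurable number, since compound 3 still gives 100 nM, but replacing it with methyl costs more than the aryl change did. No data at hand explain this shift.

Still open, going by these compounds, is whether a longer chain such as ethyl, or an acetyl group, on this nitrogen would raise the number further. On these data alone, it is also open whether methyl on this nitrogen has a similar effect with the 2,6-dibromo-4-methylphenyl group of compound 2.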